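This account rests on a few compounds, and the source may have more. Where it says the series, first, only, none or still open, it means among the compounds named here.

Of the compounds shown here, two of a shared core have been tested so far. Within the data shown here, compound 1 `O=C(/C=C\Nc1ccc(C(F)(F)F)cc1)c1cn(-c2ccccc2)nc1-c1ccc(Cl)cc1` and compound 2 `COc1ccc(-c2nn(-c3ccccc3)cc2C(=O)/C=C\Nc2ccc(F)cc2)cc1` differ in two places at once, so no single step links them. In an ADME assay on HaCaT cells (Homo sapiens) for antiproliferative activity, read by MTT assay, with a stated time of 48 h (a higher number here means a weaker inhibitor, a lower number a stronger inhibitor), compound 2 gives 8910 nM. In this assay compound 1 gives only a limit, > 50000 nM. Among the measured compounds shown here, compound 2 therefore stands as the one real number among the two results, while the other result sits at the limit of > 50000 nM in this assay, at which 1 of the 2 values shown sits, rather than at a measured point.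

Compound 3 `COc1ccc(-c2nn(-c3ccccc3)cc2C(=O)/C=C\Nc2ccc(C(F)(F)F)cc2)cc1` is the next compound, and it is reached from compound 2 by one change: trifluoromethyl in place of fluoro on an aromatic carbon. Compound 1 carries the same trifluoromethyl-bearing anilino group, and its reading was a limit. On that basis the step from compound 2 to compound 3 is expected to weaken inhibition, with a step of a 2.8-fold higher number from compound 2 to compound 3 (0.45 log units; beyond the scatter) in this assay, larger than the usual scatter, though this rests on a single limit and not on a measured step. The expected value for compound 3 is estimated at 25000 nM, within a range from 8000 nM to 60000 nM.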

Compound 3, half-maximal inhibitory concentration: > 50000 nM
Compound 3 ended at the assay's limit (the forecaster's own chance of this, stated with the estimate: 35%); middle value at least 2.0-fold (0.30 log units) from the limit.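

Among these compounds, this is the first change at this position that can be read on its own: trifluoromethyl in place of fluoro on an aromatic carbon, para to a large group, gives an at least 5.6-fold higher number from compound 2 to compound 3 (0.74 log units; beyond the scatter), a minimum that lies beyond the scatter, so the true step may be larger. In this assay compound 3 gives > 50000 nM, which is a limit and not a number. The step from compound 1 to compound 3, methoxy in place of chloro on an aromatic carbon, cannot be read, since both of its ends are limits, and so it says nothing about that change: the limit of > 50000 nM in this assay, at which 2 of the 3 values shown sit.

Among the compounds shown here, only one pair of groups has been compared on this carbon, so it remains open whether the loss is particular to trifluoromethyl or would also follow from other groups there, such as a methyl, a nitrile or an amine. As far as these compounds go, it also remains open whether chloro and methoxy differ at all, which would take a pair carrying fluoro on the anilino group, where a measured number is more likely than a limit.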